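The compounds below may be only part of what the source reports. "The series", "measured", "known", "first", "only" and "open" are said of these compounds alone.

Working notes on the series. Of the compounds shown here, two have numbers so far: compound 1 `Cc1cc(NC(=O)C2CCOC2)nn1Cc1cc(Cl)ccc1OCc1ccccc1` and compound 2 `CCOC(=O)Nc1cc(C)n(Cc2cc(Cl)ccc2OCc2ccccc2)n1`. In an assay on CHO-K1 cells for displacement of a labelled ligand from prostaglandin E2 receptor EP1 subtype (Homo sapiens) (on this read-out higher numbers stand for weaker inhibition and lower numbers for stronger inhibition), compound 1 gives 39.8 nM, and compound 2 gives 79.4 nM. For the measured compounds named here, the one step between them, a 2.0-fold higher number from compound 1 to compound 2 (0.30 log units; within the scatter), is the whole basis available for this part of the molecule. On the numbers shown, compound 2 holds the higher of the two values, with compound 1 as its only neighbour, and the gap between them does not exceed the scatter, so no order between compound 1 and compound 2 can be claimed.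

The next compound, compound 3 `COC(=O)Nc1cc(C)n(Cc2cc(Cl)ccc2OCc2ccccc2)n1`, has not been measured. It differs from compound 2 in one place: hydrogen in place of methyl on a saturated chain carbon bound to an oxygen next to a carbonyl group. Going by the values given here, the only measured step that touches this group is the one from compound 1 to compound 2, and it stayed within the scatter, so a change on the carbonyl-attached group has so far left this assay essentially unmoved. A smaller change at the same site is therefore expected to do the same, with no step beyond the scatter in either direction: the step from compound 2 to compound 3 is estimated at a 1.0-fold higher number from compound 2 to compound 3 (0.00 log units; within the scatter). Compound 3 is expected to give about 80 nM in this assay, with a range from 32 nM to 200 nM.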

Compound 3, half-maximal inhibitory concentration in the prostaglandin E2 receptor EP1 subtype assay: 200 nM
Beside the measured number, compound 3's estimate is 2.5-fold (0.40 log units) below it; the measured number falls inside the stated range.
By their numbers in the prostaglandin E2 receptor EP1 subtype assay, from the lowest: compounds 1 and 2 (each within the scatter of the next); then compound 3.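

For the compounds shown here, in the prostaglandin E2 receptor EP1 subtype assay, the change from ethoxy to methoxy on the carbonyl carbon gives a 2.5-fold higher number from compound 2 to compound 3 (0.40 log units; beyond the scatter), so this site does respond to a change as small as ethyl to methyl, which the earlier compounds gave no sign of. The wider comparison points the same way: a 5.0-fold higher number from compound 1 to compound 3 (0.70 log units; beyond the scatter), whereas a 2.0-fold higher number from compound 1 to compound 2 (0.30 log units; within the scatter), so methoxy is set apart from both oxolan-3-yl and ethoxy, while those two cannot be ordered. In a physicochemical assay for lipophilicity, at pH 7.4 (a higher number here means a more lipophilic compound, a lower number a more polar compound), compound 2 gives > 3.7, which is a limit of the assay and not a number. In the physicochemical assay compound 3 gives > 3.7, which is also a limit of the assay and not a number. No lipophilicity difference can be read for the change from ethoxy to methoxy, and the step in the physicochemical assay cannot be read, because both compounds sit at a limit of that assay rather than at a number: the limit of > 3.7 in the physicochemical assay, at which 2 of the 2 values shown sit.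

From the compounds shown here alone, what remains open is how a longer chain such as propoxy, a branched group such as isopropoxy, or an amine such as dimethylamino on the carbonyl carbon would read in the prostaglandin E2 receptor EP1 subtype assay. With a single step between ethoxy and methoxy, the shift cannot yet be tied to chain length or to any other cause, and it is known only on this one shared core.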